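This account rests on a few compounds, and the source may have more. Where it says the series, first, only, none or still open, it means among the compounds named here.

Measured in a functional assay on HeLa cells (Homo sapiens) for cytotoxicity, read by resazurin assay, with a stated time of 72 h; on this read-out lower numbers stand for stronger inhibition and higher numbers for weaker inhibition:
- compound 1 `CCNC(=S)SCC(=O)c1ccc(OC)cc1`: 7800 nM
- compound 2 `CCOC(=O)SCC(=O)c1ccc(OC)cc1`: 18500 nM

Of these two compounds, compound 2 stands higher, at 18500 nM, and so is the weaker inhibitor. Compound 3 `CCNC(=O)SCC(=O)c1ccc(OC)cc1` has ethylamino in place of ethoxy on a carbonyl carbon. For the measured compounds named here, only one measured step bears on this change: a 2.4-fold higher number from compound 1 to compound 2 (0.38 log units; beyond the scatter). That step also exchanges ethylamino and ethoxy, in the opposite sense, but it alters more of the group than this alone, so only part of it is expected to return. In this assay, the expected step is therefore a small one towards a lower number, a 1.5-fold lower number from compound 2 to compound 3 (0.19 log units; within the scatter). For compound 3 the estimated value is 12000 nM, with an expected range from 5500 nM to 26000 nM.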

Compound 3, half-maximal inhibitory concentration: 13300 nM
The estimate for compound 3 lay 1.1-fold (0.04 log units) below the measured number, and the stated range covers the measured number.
By their numbers in this assay, from the lowest: compounds 1, 3 and 2 (each within the scatter of the next, the first and the last beyond it).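

In this assay, the gap between the two earlier compounds now divides into two smaller parts: ethylamino in place of ethoxy on a carbonyl carbon accounts for a 1.4-fold lower number from compound 2 to compound 3 (0.14 log units; within the scatter) and the exchange of the thiocarbonyl of compound 1 for a carbonyl accounts for a 1.7-fold higher number from compound 1 to compound 3 (0.23 log units; within the scatter) in the same series. Each part lies within the scatter, so neither exchange alone can be told apart from repeat variation, although the two together, as in a 2.4-fold higher number from compound 1 to compound 2 (0.38 log units; beyond the scatter), lie beyond it. Nothing available here explains these numbers.

From the compounds shown here alone, it remains open whether a longer chain such as butylamino, or a dimethylamino group, on the carbonyl carbon would give a clearer step. The effect of replacing the methoxy group of the shared core with a hydroxyl or a chlorine is also unknown.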